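The compounds below may be only part of what the source reports. "The series", "measured", "known", "first", "only" and "open" are said of these compounds alone.

Measured compounds:
- Compound 1, `Cc1ccc2nc(C(=O)Nc3c(F)cc(-c4cccc(F)c4)cc3F)c(C)c(O)c2c1`, gives 17.9%.
- Compound 2, `COc1ccc2nc(C(=O)Nc3ccc(-c4ccccc4)cc3)c(C)c(O)c2c1`, gives 36.2%.
- Compound 3, `Cc1ccc2nc(C(=O)Nc3c(F)cc(-c4cccc(F)c4)cc3F)c(C)c(C(=O)O)c2c1`, gives 19.2%.

All three were tested in a functional assay on A-375 cells (Homo sapiens) for antiproliferative activity, read by MTT assay, with a stated time of 24 h, tested at 11.11 ug/mL; on this read-out higher numbers stand for a stronger effect at the one concentration tested and lower numbers for a weaker effect. Compound 1 and compound 3 share a core and differ in one place, (carboxy in place of hydroxy on an aromatic carbon). This change moved the read-out by a number 1.3 percentage points higher from compound 1 to compound 3 (within the scatter), so the two compounds cannot be told apart on this measurement. Compound 2 stands highest of the three: its value lies beyond the scatter above that of compound 3 and beyond the scatter above that of compound 1. How the core of compound 2 differs from the core of compound 1 is not broken down here.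

Compound 4, `COc1ccc2nc(C(=O)Nc3ccc(-c4ccccc4)cc3)c(C)c(C(=O)O)c2c1`, has not been measured yet. It stands to compound 2 as compound 3 stands to compound 1: the change is carboxy in place of hydroxy on an aromatic carbon, and the surroundings of the place are the same as in the change from compound 1 to compound 3. Since that earlier change left the read-out essentially where it was, compound 4 is expected to sit close to compound 2, with an estimated step of a number 0.8 percentage points higher from compound 2 to compound 4 (within the scatter) in this assay, resting on the step of a number 1.3 percentage points higher from compound 1 to compound 3 (within the scatter). Compound 4 is therefore estimated at 37%, with a likely range from 25% to 49%.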

Compound 4, a percentage reported as inhibition, at one concentration (the size of the read-out at that concentration, not a potency): 47.9%
Estimate against measurement, compound 4: 10.9 percentage points below, within the range that was stated.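

On the core of compound 2, carboxy in place of hydroxy on an aromatic carbon, opposite the ring nitrogen, gave a modest step in this assay: a number 11.7 percentage points higher from compound 2 to compound 4 (beyond the scatter). Set beside the same change on the other core, this step cannot be told apart from the earlier one, even though only one of the two lies beyond the scatter: the same change on two cores in this assay, a number 1.3 percentage points higher (within the scatter) from compound 1 to compound 3 and a number 11.7 percentage points higher (beyond the scatter) from compound 2 to compound 4, 10.4 percentage points apart, within the scatter of two such steps This shows that the two cores give no measurable sign of responding differently to the change, but it does not show that the step has a fixed size, that it will be a gain on every core, or that it would carry to a third core, since only two pairs tested at one concentration are available.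

On these data alone, only hydroxy and carboxy appear at this place, so it remains open how an amine, a methyl ester or a primary amide there would read in this assay. The two cores also differ in more than one place, which leaves open how the methoxy and methyl groups and the fluorine atoms each bear on the read-out or on the size of the step.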